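The compounds below may be only part of what the source reports. "The series", "measured", "known", "first", "only" and "open" are said of these compounds alone.

Measured compounds:
Compound 1, `CC1CCCCC1Oc1cccc2ccc(N)nc12`, in an assay on cells with melanin-concentrating hormone receptor 1 (Homo sapiens) as the target, read by radioligand binding (on this read-out lower numbers stand for stronger inhibition and higher numbers for weaker inhibition), gives 32 nM.
Compound 2, `CC(CC(C)(C)C)Oc1cccc2ccc(N3CCCC3)nc12`, in this assay gives > 2000 nM, which is a limit of the assay and not a number.
Compound 3, `CC(CC(C)(C)C)Oc1cccc2ccc(N3CCCCC3)nc12`, in this assay gives > 2000 nM, again a limit of the assay and not a number.

Compound 3 therefore stands at the upper edge of what this assay can report, sharing the limit of > 2000 nM in this assay, at which 2 of the 3 values shown sit, with compound 2. Among the compounds with values here, the single measured step, a step that the two limits leave unreadable from compound 2 to compound 3, runs between two limits and so cannot be read in size or direction.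

Compound 4, `CNc1ccc2cccc(OC(C)CC(C)(C)C)c2n1`, carries a different group at the same position: methylamino in place of piperidin-1-yl on an aromatic carbon. Within the data shown here, no measured step shows this exchange. Among the measured compounds shown here, compound 1 is the only compound here with a value and not a limit, and it differs from compound 4 in two places at once, so its number can be noted but not turned into a step.

What can be said is that the two compounds with a ring on that carbon both sit at the limit, while compound 1 with a small amino group gives a number. On that basis compound 4 is expected to bind more strongly than compound 3, with the step of an at least 8.0-fold lower number from compound 3 to compound 4 (0.90 log units; beyond the scatter) uncertain in size. For compound 4 the estimate is 250 nM, within 30 nM to 2000 nM.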

Compound 4, half-maximal inhibitory concentration: 310 nM
Estimate against measurement, compound 4: 1.2-fold (0.09 log units) below; measured number inside the range.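

With the rest of the molecule held fixed, this position now yields a measured number and not only a limit: in this assay, the exchange for methylamino gives an at least 6.4-fold lower number from compound 3 to compound 4 (0.80 log units; beyond the scatter), and the same exchange starting from the five-membered ring gives an at least 6.4-fold lower number from compound 2 to compound 4 (0.80 log units; beyond the scatter). Within the data shown here, the earlier compounds showed only that two ring-bearing amines on this aromatic carbon, next to the ring nitrogen, sit at the same edge of the assay, whereas this result shows that a change at this one place can move binding into the readable range. Both steps give only a minimum size and not a true size, because compound 2 and compound 3 each stand at a limit of the assay and not at a number: the limit of > 2000 nM in this assay, at which 2 of the 4 values shown sit.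

The exchange removes a ring, shrinks the group and adds a hydrogen-bond donor all at once, the compounds shown do not separate these changes, and the step between the two ring compounds cannot be read. Dimethylamino or ethylamino at this position on the same core would speak to that question, and how much stronger binding can become through this position also stays open.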